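Removing One Methoxy Group from Compound 2

The source may hold more compounds than are shown below. What is called first, only, known or untested is meant among the compounds shown, and "the series" means these compounds.

Measured in a functional assay on P388D1 cells (Homo sapiens) for antiproliferative activity, read by sulforhodamine B assay, with a stated time of 48 h; a lower number here means a stronger inhibitor, a higher number a weaker inhibitor:
- compound 1 `O=C1NCCN1c1ccc(S(=O)(=O)Nc2cccc(Cl)c2)cc1`: 78 nM
- compound 2 `COc1cc(NS(=O)(=O)c2ccc(N3CCNC3=O)cc2)cc(OC)c1`: 200 nM

Only these two compounds have been measured so far, and they do not differ in a single place. Compound 2 holds the higher number of the pair, which makes it the weaker inhibitor of the two. Compound 1 stands at 78 nM and compound 2 at 200 nM, a gap that lies beyond the usual scatter.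

The next compound, compound 3 `COc1cccc(NS(=O)(=O)c2ccc(N3CCNC3=O)cc2)c1`, departs from compound 2 in one place: hydrogen in place of methoxy on an aromatic carbon. In words, hydrogen takes the place of methoxy on an aromatic carbon, and one methoxy group remains.

Among the compounds with values here, no measured pair shows this change on its own, so the expectation rests on little. In this assay a small move toward a lower number is expected, probably not beyond the scatter. Within the data shown here, the only hint is that compound 1, which carries no methoxy group, gives 78 nM. The expected change is a 1.4-fold lower number from compound 2 to compound 3 (0.15 log units; within the scatter). For compound 3 the estimated value is 140 nM, with an expected range from 50 nM to 400 nM.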

Compound 3, half-maximal inhibitory concentration: 250 nM
For compound 3 the middle estimate is 1.8-fold (0.25 log units) below the measured one, and the stated range covers the measured number.
By their numbers in this assay, from the lowest: compound 1; then compounds 2 and 3 (each within the scatter of the next).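

Hydrogen in place of methoxy on this aromatic carbon gives a 1.3-fold higher number from compound 2 to compound 3 (0.10 log units; within the scatter) in this assay, so this pair does not separate a ring with one methoxy group from a ring with two. Within the data shown here, the first step beyond the scatter at a single place comes from methoxy in place of chloro on an aromatic carbon, which gives a 3.2-fold higher number from compound 1 to compound 3 (0.51 log units; beyond the scatter); in this one pair, then, the identity of the group remaining on the ring registers in the read-out, while the removal of the other methoxy group does not. Nothing available here offers an independent measurement that would explain either step.

The compounds shown leave open how an amine, a hydroxyl group or a longer chain such as ethoxy would read on this aromatic carbon, and whether a ring carrying hydrogen in place of the remaining methoxy group would stand closer to compound 1 or to compound 3. As far as these compounds go, the contrast between chloro and methoxy also rests on a single pair, so whether it holds elsewhere on the ring remains unknown.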